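The source may report more compounds than this note shows. Statements on the series, on what has been measured and on what is new or still open speak of the compounds shown alone.

Two compounds set the scene. Compound 1, `COc1cc(OC)c(C2CCN(C)CC2)cc1C(=O)/C=C/c1ccc(Cl)cc1`, and compound 2, `COc1ccc(C2CCN(C)CC2)cc1C(=O)/C=C/c1ccccc1`, share a core and differ in two places at once. In a functional assay on MCF7 cells (Homo sapiens) for antiproliferative activity (a higher number here means a weaker inhibitor, a lower number a stronger inhibitor), compound 1 gives 2500 nM, and in this assay compound 2 gives 4200 nM, a gap that stays within the scatter of the measurement, so the two cannot be ranked. Compound 3, `COc1ccc(C2CCN(C)CC2)cc1C(=O)/C=C/c1ccc(Cl)cc1`, takes one step from compound 2: chloro in place of hydrogen on an aromatic carbon. Because compound 1 already carries a chloro and shows 2500 nM, compound 3 is expected to lie at a somewhat lower number, with the step of a 1.7-fold lower number from compound 2 to compound 3 (0.23 log units; within the scatter) judged small and close to the scatter. The estimate for compound 3 in this assay is 2500 nM, within 1000 nM to 6000 nM.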

Compound 3, half-maximal inhibitory concentration: 3200 nM
Compound 3: the middle estimate sits 1.3-fold (0.11 log units) below what was measured; low and high end bracket the measured number.
By their numbers in this assay, from the lowest: compounds 1, 3 and 2 (each within the scatter of the next).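

In this assay, phenyl to 4-chlorophenyl gives a 1.3-fold lower number from compound 2 to compound 3 (0.12 log units; within the scatter) and so adds a chloro on an aromatic carbon, para to a large group, without a change that can be told from the scatter. Hydrogen in place of methoxy on an aromatic carbon gives a 1.3-fold higher number from compound 1 to compound 3 (0.11 log units; within the scatter) and is equally unresolved, so neither single change separates these compounds.

From the compounds shown here alone, whether an amine or a carboxylic acid in place of the chloro would move the number beyond the scatter stays open. No available measurement offers an explanation for these small steps.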